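The compounds below may be only part of what the source reports. "The series", "measured", "known", "first", "only" and "open" are said of these compounds alone.

Measured in an ADME assay on HeLa cells (Homo sapiens) for antiproliferative activity, read by MTT assay, with a stated time of 72 h, tested at 10 ug/mL; on this read-out higher numbers stand for a stronger effect at the one concentration tested and lower numbers for a weaker effect:
compound 1 `O=C1CSc2ccccc2N1Cc1cn(-c2ccc([N+](=O)[O-])cc2)nn1`, -0.9%
compound 2 `O=C1CSc2ccccc2N1Cc1cn(Cc2cccc([N+](=O)[O-])c2)nn1`, -3%

Compound 2 and compound 1 lie within the usual scatter of each other in this assay, and both sit at essentially no effect at the single concentration tested. Compound 3 `O=C1CSc2ccccc2N1Cc1cn(Cc2ccc([N+](=O)[O-])cc2)nn1` is not yet measured. It differs from compound 2 as follows: 4-nitrophenyl in place of 3-nitrophenyl on a saturated chain carbon bound to an aromatic nitrogen. Going by the values given here, no step between measured compounds carries this same change, so the move rests only on the two values shown. Since compound 2 gives -3% and compound 1 gives -0.9%, no step beyond the scatter is expected in this assay in either direction. Compound 3 is expected to give -1%, between -10% and 8%, an expected step of a number 2 percentage points higher from compound 2 to compound 3 (within the scatter).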

Compound 3, a percentage reported as activity, at one concentration (the size of the read-out at that concentration, not a potency) in the HeLa assay: 53.2%
For compound 3 the middle estimate is 54.2 percentage points below the measured one; measured number above the stated range.
By their numbers in the HeLa assay, from the lowest: compounds 2 and 1 (each within the scatter of the next); then compound 3.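

The position on the saturated chain carbon bound to an aromatic nitrogen is sensitive to where the nitro group sits on the phenyl ring: in the HeLa assay, compound 2 gives -3% and compound 3 gives 53.2%, so 4-nitrophenyl in place of 3-nitrophenyl gives a number 56.2 percentage points higher from compound 2 to compound 3 (beyond the scatter) and the atoms stay the same. In a physicochemical assay, read by spectrophotometry (on this read-out higher numbers stand for weaker inhibition and lower numbers for stronger inhibition), compound 2 gives 34.1 ug/mL and compound 3 gives 27.4 ug/mL; the same change gives a 1.2-fold lower number from compound 2 to compound 3 (0.10 log units; within the scatter) and so does not carry over to that read-out. Nothing available explains the step.

Going by these compounds, whether the effect requires the nitro group remains open, as a nitrile or a carboxylic acid on the same ring could show. On these data alone, with one concentration tested, the potency of compound 3 also remains open.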